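The compounds below may be only part of what the source reports. "The series", "measured", "known", "first", "only" and "open" are said of these compounds alone.

Measured compounds in an assay on HEK293 cells for displacement of a labelled ligand from 5-hydroxytryptamine receptor 6 (Homo sapiens), with a stated time of 60 min, tested at 1 uM, in the presence of a further agent that is not named here; on this read-out higher numbers stand for a stronger effect at the one concentration tested and lower numbers for a weaker effect:
compound 1 `COc1ccc(S(=O)(=O)N2CCC(CCC(=O)c3cc(Cl)c(N)cc3OC)CC2)cc1`: "not active" (no number reported)
compound 2 `COc1ccc(S(=O)(=O)NCCN2CCC(CCC(=O)c3cc(Cl)c(N)cc3OC)CC2)cc1Cl`: 85%
compound 3 `COc1ccc(S(=O)(=O)NCCCN2CCC(CCC(=O)c3cc(Cl)c(N)cc3OC)CC2)cc1`: "not active" (no number reported)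

Among the compounds with values here, compound 2 holds the only number reported in this assay; compound 1 and compound 3 are each reported without a number, so no numerical comparison between them and compound 2 can be drawn, and no step between measured compounds is available.

Compound 4 `COc1cc(N)c(Cl)cc1C(=O)CCC1CCN(CCNS(=O)(=O)c2ccc(NC(C)=O)cc2)CC1` is not yet measured. It differs from compound 2 in one place: 4-acetamidophenyl in place of 3-chloro-4-methoxyphenyl on a sulfonyl sulfur. The sulfonamide nitrogen and the remainder of the molecule are unchanged.

Within the data shown here, with no measured step to lean on, the expectation for this assay rests on compound 2 alone, which gives 85%. The change replaces the 3-chloro-4-methoxyphenyl with a 4-acetamidophenyl on the sulfonyl sulfur; how this read-out responds to such a swap is not shown by any pair here. Among the measured compounds shown here, a step beyond the scatter in either direction cannot be excluded, and a drop of moderate size is taken as the more likely outcome given that only one compound of the three reached a reported number.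

Compound 4 is therefore expected to give about 60%, within a range from 25% to 85%. The step this estimate means is a number 25 percentage points lower from compound 2 to compound 4 (beyond the scatter), expected to be a loss beyond the scatter.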

Compound 4, a percentage reported as inhibition, at one concentration (the size of the read-out at that concentration, not a potency): 67%
For compound 4 the middle estimate is 7 percentage points below the measured one, within the range that was stated.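

Working notes on the sulfonyl aryl group. In this assay, within the data shown here, with the sulfonamide nitrogen and the rest of the molecule unchanged, 4-acetamidophenyl in place of 3-chloro-4-methoxyphenyl on a sulfonyl sulfur gives a number 18 percentage points lower from compound 2 to compound 4 (beyond the scatter), the only single-place comparison available. The group on the sulfonyl sulfur therefore affects the read-out, yet this exchange does not abolish it: compound 4 still gives 67%, even though the entering group has a hydrogen-bond donor that the leaving group lacks and no chlorine. Nothing measured here explains the loss.

On these data alone, it remains open whether the step comes from losing the chlorine, losing the methoxy or gaining the acetamido group, and how a simple phenyl, a free amine or a carboxylic acid on that ring would read out. Steps involving compound 1 and compound 3 cannot be read, as neither has a reported number, so the contribution of the chain joining the sulfonamide nitrogen to the shared core also stays unresolved.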